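Varying the aryl group on a fatty-acid amide hydrolase inhibitor

The compounds below may be only part of what the source reports. "The series", "measured", "known", "first", "only" and "open" are said of these compounds alone.

Compound 1, `O=C(CCCCCCc1ccccc1)c1ncc(-c2ccc(F)cc2)o1`: 62 nM
Compound 2, `O=C(CCCCCCc1ccccc1)c1ncc(-c2ccc(O)cc2)o1`: 140 nM
Compound 3, `N#Cc1ccc(-c2cnc(C(=O)CCCCCCc3ccccc3)o2)cc1`: 40 nM

In an assay (Rattus norvegicus) for inhibition of Fatty-acid amide hydrolase 1 (Homo sapiens) (a higher number here means a weaker inhibitor, a lower number a stronger inhibitor), compound 3 gives 40 nM, the lowest of the three numbers. One step leading to it is a 1.6-fold lower number from compound 1 to compound 3 (0.19 log units; within the scatter), which stays within the scatter, so the two cannot be ordered; the other step leading to it, a 3.5-fold lower number from compound 2 to compound 3 (0.54 log units; beyond the scatter), lies beyond the scatter.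

Compound 4, `O=C(CCCCCCc1ccccc1)c1ncc(-c2cncnc2)o1`, has not yet been measured. It differs from compound 3 in one place: pyrimidin-5-yl in place of 4-cyanophenyl on an aromatic carbon.

Among the measured compounds shown here, two measured steps touch the same position. Replacing fluoro by cyano gave a 1.6-fold lower number from compound 1 to compound 3 (0.19 log units; within the scatter), a change within the scatter; replacing hydroxy by cyano gave a 3.5-fold lower number from compound 2 to compound 3 (0.54 log units; beyond the scatter), a modest change. For the measured compounds named here, neither exchanges the six-membered carbon ring itself for a ring holding two nitrogen atoms, so no measured step speaks directly to the change in compound 4. The recorded steps show that this position tolerates several groups with modest shifts at most. Compound 4 is therefore expected to land close to compound 3, with a small rise allowed: the estimated step is a 2.3-fold higher number from compound 3 to compound 4 (0.35 log units; beyond the scatter). The estimate for compound 4 is 90 nM, within 35 nM to 250 nM.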

Compound 4, inhibition constant: 22 nM
Compound 4: middle estimate off by 4.1-fold (0.61 log units), on the high side; the whole stated range lies above it.
By their numbers in this assay, from the lowest: compounds 4, 3 and 1 (each within the scatter of the next, the first and the last beyond it); then compound 2.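

The earlier compounds shown here varied only the group carried on a carbon-only ring, whereas compound 4 shows that in this assay the ring itself can be exchanged for one with 2 hetero atoms, with the nitrile gone as well, and the number stays close: a 1.8-fold lower number from compound 3 to compound 4 (0.26 log units; within the scatter) lies within the scatter, so these two compounds cannot be ordered. The same exchange separates compound 4 from the other two aryl compounds, with a 2.8-fold lower number from compound 1 to compound 4 (0.45 log units; beyond the scatter) and a 6.4-fold lower number from compound 2 to compound 4 (0.80 log units; beyond the scatter), both beyond the scatter, so among these four compounds a substituted carbon-only ring is not needed for a low number at this place. The data offer no measured finding that accounts for this result.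

The compounds shown leave open whether the result depends on having both ring nitrogens, which pyridin-3-yl, with a single ring nitrogen, would test, and whether pyrimidin-5-yl would tolerate an added amine or carboxylic acid. They also leave open whether the same ring exchange would hold with a longer chain on the carbonyl.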